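Swapping the Five-Membered Ring on a Fluorinated Nucleoside

The compounds below may be only part of what the source reports. "The series", "measured", "known", "first", "only" and "open" are said of these compounds alone.

- Compound 1 `OC[C@H]1O[C@@H](n2cc(F)c3c(-c4cccs4)ncnc32)[C@H](O)[C@@H]1O` gives 4300 nM
- Compound 2 `OC[C@H]1O[C@@H](n2cc(F)c3c(-c4nccs4)ncnc32)[C@H](O)[C@@H]1O` gives 3100 nM
- Compound 3 `OC[C@H]1O[C@@H](n2cc(F)c3c(-c4ccc[nH]4)ncnc32)[C@H](O)[C@@H]1O` gives 230 nM

In a functional assay on HeLa S3 cells (Homo sapiens) for cytotoxicity, read by XTT assay, with a stated time of 3 days (on this read-out higher numbers stand for weaker inhibition and lower numbers for stronger inhibition), compound 1 gives 4300 nM. That places it at the weak end of this small set, within the scatter of compound 2, while compound 3 lies well beneath both. The next compound, compound 4 `OC[C@H]1O[C@@H](n2cc(F)c3c(-c4ccoc4)ncnc32)[C@H](O)[C@@H]1O`, keeps the shared core and carries furan-3-yl in place of thiophen-2-yl on an aromatic carbon.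

Two measured exchanges of the same ring bear on this change. Putting in 1,3-thiazol-2-yl gave a 1.4-fold lower number from compound 1 to compound 2 (0.14 log units; within the scatter), while putting in 1H-pyrrol-2-yl gave a 19-fold lower number from compound 1 to compound 3 (1.27 log units; beyond the scatter). Going by the values given here, no measured compound carries furan-3-yl, so these steps only mark out what such a swap has done here: nothing beyond the scatter in one case, a large drop in the other. A modest move towards a lower number in this assay therefore seems the fair expectation, though it may not clear the scatter. The expected step is a 3.3-fold lower number from compound 1 to compound 4 (0.52 log units; beyond the scatter). The estimate for compound 4 is 1300 nM, with an expected range of 250 nM to 5000 nM.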

Compound 4, half-maximal inhibitory concentration: 170 nM
For compound 4 the middle estimate is 7.6-fold (0.88 log units) above the measured one; measured number below the stated range.
By their numbers in this assay, from the lowest: compounds 4 and 3 (each within the scatter of the next); then compounds 2 and 1 (each within the scatter of the next).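

Until now only 1H-pyrrol-2-yl had brought a large drop at this aromatic carbon, but furan-3-yl, which has 0 hydrogen-bond donors, does so as well, with a 25-fold lower number from compound 1 to compound 4 (1.40 log units; beyond the scatter) in this assay and an 18-fold lower number from compound 2 to compound 4 (1.26 log units; beyond the scatter) on the same read-out. The two low compounds stand level, with a 1.4-fold lower number from compound 3 to compound 4 (0.13 log units; within the scatter), so a large drop here does not depend on 1H-pyrrol-2-yl alone, and thiophen-2-yl and furan-3-yl can sit far apart despite matching heavy-atom counts. Nothing measured here explains this gap between two such similar rings.

Furan-3-yl differs from thiophen-2-yl in both its hetero atom and its point of attachment, so thiophen-3-yl or furan-2-yl would be needed to tell these two changes apart. On these data alone, whether anything other than a five-membered aromatic ring, such as an amine or a carboxylic acid, is tolerated on this carbon also stays open.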